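The source may report more compounds than this note shows. Statements on the series, on what has been measured and on what is new or still open speak of the compounds shown alone.

Compound 1 (`CC(C)=CC[C@@H](OC(=O)c1ccco1)C1=CC(=O)c2c(O)ccc(O)c2C1=O`) gives > 100000 nM in a functional assay on DU-145 cells (Homo sapiens) for cytotoxicity, read by MTT assay (on this read-out lower numbers stand for stronger inhibition and higher numbers for weaker inhibition), and this is a limit of the assay and not a number. Among the measured compounds shown here, it is the only limit so far: the limit of > 100000 nM in this assay, at which 1 of the 3 values shown sits. Compound 2 (`CC(=O)OCCO[C@H](CC=C(C)C)C1=CC(=O)c2c(O)ccc(O)c2C1=O`) gives 15500 nM, and compound 3 (`COCCO[C@H](CC=C(C)C)C1=CC(=O)c2c(O)ccc(O)c2C1=O`) gives 43200 nM.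

Compound 4 (`CCCC(CC(=O)O[C@H](CC=C(C)C)C1=CC(=O)c2c(O)ccc(O)c2C1=O)OC(C)=O`) keeps the ester of compound 1 and differs from it as follows: 2-acetoxypentyl in place of furan-2-yl on a carbonyl carbon. For the measured compounds named here, no measured step makes this change on the carbonyl carbon. The nearest evidence replaces the whole (furan-2-yl)carbonyl on the oxygen: an at least 6.4-fold lower number from compound 1 to compound 2 (0.80 log units; beyond the scatter), and an at least 2.3-fold lower number from compound 1 to compound 3 (0.36 log units; beyond the scatter). On these data alone, both steps lead to a lower number, and both start from the limit, so their true sizes remain open. Methyl in place of acetyl gives a 2.8-fold higher number from compound 2 to compound 3 (0.45 log units; beyond the scatter), so the acetoxy-bearing compound 2, at 15500 nM, is the closer guide for compound 4, which also carries an acetoxy group.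

A modest move to a lower number is expected in this assay, with a real chance that the result stays at the limit. The expected change is an at least 3.3-fold lower number from compound 1 to compound 4 (0.52 log units; beyond the scatter). Compound 4 is estimated at 30000 nM, within an expected range of 9000 nM to 100000 nM.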

Compound 4, half-maximal inhibitory concentration: 55700 nM
The estimate for compound 4 lay 1.9-fold (0.27 log units) below the measured number; measured number inside the range.
By their numbers in this assay, from the lowest: compound 2; then compounds 3 and 4 (each within the scatter of the next). At a limit, above all of these: compound 1.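

With the ester kept, 2-acetoxypentyl in place of furan-2-yl on a carbonyl carbon gives, in this assay, an at least 1.7-fold lower number from compound 1 to compound 4 (0.25 log units; that floor lies within the scatter). This is the first change shown at this carbonyl carbon, and compound 4 shows that an ester on this oxygen can give a measured number and not a limit. The size of the step stays unsettled, as compound 1 carries a limit and not a number: the limit of > 100000 nM in this assay, at which 1 of the 4 values shown sits.

Compound 4 brings in the acetoxy group and the carbon chain together, leaving the share of each open. Also open, on these data alone, is how an amine, a carboxylic acid or a plain pentyl chain on the same carbonyl carbon would read in this assay.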